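Trimming the Bicyclic Ring Group to a Single Small Ring

The source may hold more compounds than are shown below. What is called first, only, known or untested is meant among the compounds shown, and "the series" means these compounds.

Compound 3 `CCCCCCCCc1ccc(OCC(=O)Cn2ccc3ncccc32)cc1` shares its long-chain phenyl ether core with compound 1 `CCCCCCCCc1ccc(OCC(=O)Cn2cnc3ccccc32)cc1` and compound 2 `CCCCCCCCc1ccc(OCC(=O)Cn2cnc3cccnc32)cc1`; the three differ only in the ring group sitting on a saturated chain carbon bound to a carbonyl carbon. In an assay on microsomes from brain for inhibition of Fatty-acid amide hydrolase 1 (Rattus norvegicus), read by fluorescence and HPLC, with a stated time of 60 min (on this read-out lower numbers stand for stronger inhibition and higher numbers for weaker inhibition), compound 3 gives > 10000 nM, which is a limit of the assay rather than a number. In this assay compound 1 gives 480 nM and compound 2 gives 410 nM, so compound 3 stands at the weak end of what has been measured (the limit of > 10000 nM in this assay, at which 1 of the 3 values shown sits). The steps of an at least 20-fold higher number from compound 1 to compound 3 (1.31 log units; beyond the scatter) and an at least 24-fold higher number from compound 2 to compound 3 (1.38 log units; beyond the scatter) show that exchanging a five-membered aromatic ring with 2 hetero atoms for one with 1 hetero atom was costly, whereas a 1.2-fold lower number from compound 1 to compound 2 (0.07 log units; within the scatter) shows that altering the six-membered ring gave no change beyond the scatter. Compound 4 `CCCCCCCCc1ccc(OCC(=O)Cn2cnnn2)cc1` takes the next step: a group of 5 heavy atoms (1 carbon, 4 nitrogen; one five-membered aromatic ring with 4 hetero atoms) in place of a group of 9 heavy atoms (7 carbon, 2 nitrogen; one five-membered aromatic ring with 1 hetero atom, one six-membered aromatic ring with 1 hetero atom), on a saturated chain carbon bound to a carbonyl carbon. The six-membered ring is gone and a five-membered aromatic ring with 4 hetero atoms takes the place of the ring with 1 hetero atom, so a move back toward the range of compound 1 and compound 2 is expected, although the smaller group makes the size uncertain. Compound 4 is therefore estimated at 3000 nM, between 500 nM and 20000 nM, an expected shift of an at least 3.3-fold lower number from compound 3 to compound 4 (0.52 log units; beyond the scatter).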

Compound 4, half-maximal inhibitory concentration: 39 nM
Compound 4: middle estimate off by 77-fold (1.89 log units), on the high side, outside the stated range (below it).
By their numbers in this assay, from the lowest: compound 4; then compounds 2 and 1 (each within the scatter of the next). At a limit, above all of these: compound 3.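

The ring group on a saturated chain carbon bound to a carbonyl carbon does not have to carry a six-membered ring: in this assay, the single ring of 1H-tetrazol-1-yl gives a 12-fold lower number from compound 1 to compound 4 (1.09 log units; beyond the scatter) and an 11-fold lower number from compound 2 to compound 4 (1.02 log units; beyond the scatter). Until now, changes at this place had either made no difference beyond the scatter or cost a great deal, whereas here a change brings a clear gain, and compound 4 is the most potent of the compounds shown. Compound 3 stands at a limit of the assay and not at a number, so the last step, an at least 250-fold lower number from compound 3 to compound 4 (2.40 log units; beyond the scatter), gives only a minimum for the size of the change: the limit of > 10000 nM in this assay, at which 1 of the 4 values shown sits.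

Compound 4 loses the six-membered ring and gains nitrogen atoms in its five-membered ring in the same change, and the compounds shown cannot separate these two differences. On these data alone, how a single ring with fewer nitrogen atoms, such as 1H-imidazol-1-yl, or a tetrazole ring bearing a carboxylic acid would read at this place remains open.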